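The source may hold more compounds than are shown below. What is called first, only, known or untested is meant among the compounds shown, and "the series" means these compounds.

Compounds measured in a functional assay on A549 cells (Homo sapiens) for antiproliferative activity, read by XTT assay, with a stated time of 24 h; on this read-out higher numbers stand for weaker inhibition and lower numbers for stronger inhibition:
- compound 1 `N#Cc1ccc(-c2csc(N3N=C(c4ccc(Cl)s4)CC3c3ccc(F)cc3)n2)cc1`: > 500 ug/mL
- compound 2 `Cc1ccc(C2=NN(c3nc(-c4ccc(C(F)(F)F)cc4)cs3)C(c3ccc(F)cc3)C2)s1`: > 500 ug/mL
- compound 3 `Cc1ccc(C2=NN(c3nc(-c4ccc(C#N)cc4)cs3)C(c3ccc(F)cc3)C2)s1`: 322 ug/mL

In this assay compound 1 gives > 500 ug/mL, which is a limit of the assay rather than a number. Compound 2 likewise gives > 500 ug/mL, also a limit. Compound 3 gives 322 ug/mL. Compound 1 therefore stands at the limit of > 500 ug/mL in this assay, at which 2 of the 3 values shown sit, with no measured number of its own.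

Compound 4 `COc1ccc(-c2csc(N3N=C(c4ccc(Cl)s4)CC3c3ccc(F)cc3)n2)cc1` differs from compound 1 by methoxy in place of cyano on an aromatic carbon. Within the data shown here, two measured steps bear on it. The step of an at least 1.5-fold lower number from compound 1 to compound 3 (0.19 log units; that floor lies within the scatter) changes a different site, and the step of an at least 1.5-fold lower number from compound 2 to compound 3 (0.19 log units; that floor lies within the scatter) changes the same aromatic carbon; both are floors that lie within the scatter. No step beyond the scatter is therefore expected, and the value is estimated to sit near the limit: for compound 4 the expected value is 450 ug/mL, between 150 ug/mL and 600 ug/mL, an expected step of an at least 1.1-fold lower number from compound 1 to compound 4 (0.04 log units; that floor lies within the scatter).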

Compound 4, half-maximal inhibitory concentration: > 500 ug/mL
Compound 4: a limit, no number; the forecaster's own chance of this, stated with the estimate: 60%; middle value at least 1.1-fold (0.04 log units) from the limit.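

In this assay, compound 1 and compound 4 both give a limit rather than a number, so no step between them can be read: the limit of > 500 ug/mL in this assay, at which 3 of the 4 values shown sit.

The compounds shown leave open whether changing 4-cyanophenyl to 4-methoxyphenyl alters inhibition at all.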